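Series notes: chain amine change from compound 2 to compound 3

The compounds below may be only part of what the source reports. "The series", "measured", "known", "first", "only" and "open" are said of these compounds alone.

For the measured compounds named here, compound 2 `COc1cc2c(Oc3ccc(NC(=O)c4cc(-c5ccccc5F)ccn4)cc3F)ccnc2cc1OCCCN1CCCCC1` gives 320 nM in a functional assay on HT-29 cells (Homo sapiens) for cytotoxicity, read by MTT assay, with a stated time of 72 h (a lower number here means a stronger inhibitor, a higher number a weaker inhibitor), the lowest of the two numbers available so far. Its companion compound 1 `COc1cc2c(Oc3ccc(NC(=O)c4cc(-c5ccc(F)cc5)ccn4)cc3F)ccnc2cc1OCCCN1CCCCC1` gives 1370 nM in this assay. Going by the values given here, the one measured step, a 4.3-fold lower number from compound 1 to compound 2 (0.63 log units; beyond the scatter), concerns 2-fluorophenyl in place of 4-fluorophenyl on an aromatic carbon and touches nothing else in the structure.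

Compound 3 `COc1cc2c(Oc3ccc(NC(=O)c4cc(-c5ccccc5F)ccn4)cc3F)ccnc2cc1OCCCN1CCN(C)CC1` is not yet measured. It differs from compound 2 by 4-methylpiperazin-1-yl in place of piperidin-1-yl on a saturated chain carbon, three bonds along the chain from an oxygen on an aromatic ring. Among the compounds with values here, no measured step bears on this part of the structure; the step from compound 1 to compound 2 concerns only the fluorophenyl group and says nothing about the chain amine. With nothing to go on for this change, no step beyond the scatter is expected in this assay in either direction, and the number for compound 3 is expected to sit near that of compound 2, with the range kept wide. The estimate for compound 3 is 400 nM, between 130 nM and 1300 nM, which corresponds to an expected step of a 1.3-fold higher number from compound 2 to compound 3 (0.10 log units; within the scatter).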

Compound 3, half-maximal inhibitory concentration: 220 nM
For compound 3 the middle estimate is 1.8-fold (0.26 log units) above the measured one; the range from low to high includes it.
By their numbers in this assay, from the lowest: compounds 3 and 2 (each within the scatter of the next); then compound 1.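

Chain amine, working notes: in this assay the exchange of 3-(piperidin-1-yl)propyl for 3-(4-methylpiperazin-1-yl)propyl gives a 1.5-fold lower number from compound 2 to compound 3 (0.16 log units; within the scatter) and so provides the first reading at this position, where the two compounds cannot be ordered. For the compounds shown here, the series therefore holds its cell read-out across these two ring amines in the presence of the 2-fluorophenyl group, whereas the only step beyond the scatter so far remains a 4.3-fold lower number from compound 1 to compound 2 (0.63 log units; beyond the scatter) at the fluorophenyl group, away from the chain. No supporting measurement is available to explain the result for the chain amine.

Still open, as far as these compounds go, is whether the same flat reading extends to other amines on the chain, such as morpholine or dimethylamine, or to a chain longer than propyl with either ring amine at its end. Also open is whether 4-methylpiperazin-1-yl would read the same alongside the 4-fluorophenyl group of compound 1, since the chain amine change is shown only with the 2-fluorophenyl group.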